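Methyl in place of fluoro on an aromatic carbon

The source may report more compounds than this note shows. Statements on the series, on what has been measured and on what is new or still open speak of the compounds shown alone.

Of the compounds shown here, three sharing one core have been read in a functional assay on HGC-27 cells (Homo sapiens) for inhibition, read by MTT assay, with a stated time of 72 h; a higher number here means a weaker inhibitor, a lower number a stronger inhibitor. Compound 1 `Cc1cc(N2CC[C@@H](C)[C@@H](N(C)c3ncnc4[nH]ccc34)C2)n2nc(SCc3ccc(Cl)cc3)nc2n1` gives 18400 nM, and compound 3 `Cc1cc(N2CC[C@@H](C)[C@@H](N(C)c3ncnc4[nH]ccc34)C2)n2nc(SCc3ccc(F)cc3)nc2n1` gives 26000 nM. Compound 2 `Cc1cc(N2CC[C@@H](C)[C@@H](N(C)c3ncnc4[nH]ccc34)C2)n2nc(SCc3csc4ccc(Cl)cc34)nc2n1` gives > 100000 nM, which is a limit and not a number. For the measured compounds named here, compound 3 therefore stands level with compound 1 within the scatter, and the only other reading is that limit.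

The next compound, compound 4 `Cc1ccc(CSc2nc3nc(C)cc(N4CC[C@@H](C)[C@@H](N(C)c5ncnc6[nH]ccc56)C4)n3n2)cc1`, differs from compound 3 in one substituent: methyl in place of fluoro on an aromatic carbon. The change lies para to a large group and turns 4-fluorobenzyl into 4-methylbenzyl. Going by the values given here, the closest precedent is the exchange of one substituent for another on that ring, a 1.4-fold higher number from compound 1 to compound 3 (0.15 log units; within the scatter), a step within the scatter. The larger steps, an at least 5.4-fold higher number from compound 1 to compound 2 (0.73 log units; beyond the scatter) and an at least 3.8-fold lower number from compound 2 to compound 3 (0.58 log units; beyond the scatter), both exchange the whole aromatic group and both rest on a limit, so they bear only weakly on a single substituent. No step beyond the scatter is therefore expected, and the estimated step is a 1.0-fold lower number from compound 3 to compound 4 (0.02 log units; within the scatter). For compound 4 the expected value is 25000 nM, with an estimated range from 11000 nM to 60000 nM.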

Compound 4, half-maximal inhibitory concentration: 15200 nM
The estimate for compound 4 lay 1.6-fold (0.22 log units) above the measured number; low and high end bracket the measured number.
By their numbers in this assay, from the lowest: compounds 4, 1 and 3 (each within the scatter of the next). At a limit, above all of these: compound 2.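

Methyl in place of fluoro on the aromatic carbon para to a large group gives a 1.7-fold lower number from compound 3 to compound 4 (0.23 log units; within the scatter) in this assay, and methyl in place of chloro at that carbon gives a 1.2-fold lower number from compound 1 to compound 4 (0.08 log units; within the scatter). The earlier compounds shown here compared only chloro and fluoro at this place, whereas compound 4 adds methyl, and all three now read level within the scatter, so the flat reading is no longer confined to an exchange of one halogen for another. The one kind of change that goes beyond the scatter remains the exchange of the whole aromatic group, seen again in an at least 6.5-fold lower number from compound 2 to compound 4 (0.81 log units; beyond the scatter), and that step rests on the value of compound 2, which is a limit and not a number: the limit of > 100000 nM in this assay, at which 1 of the 4 values shown sits.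

On these data alone, whether an amine, a carboxylic acid or a methoxy group at this same carbon would also read level with fluoro, chloro and methyl remains open, as does the effect of a longer chain there. Also open, as far as these compounds go, is whether a plain phenyl with no substituent, or a second ring smaller than the 5-chloro-1-benzothiophen-3-yl group, would stay with compound 4 or move beyond the scatter.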